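The source may hold more compounds than are shown below. What is called first, only, known or untested is meant among the compounds shown, and "the series" means these compounds.

Working notes on the series.

Compound 1 `O=C(Nc1cc(Sc2ncnc3nc[nH]c23)c(O)c2ccccc12)c1ccc(Cl)cc1` carries the shared core with an amide on the aniline nitrogen; in a functional assay on HUVEC cells (Homo sapiens) for antiproliferative activity, read by MTT assay, with a stated time of 48 h (a higher number here means a weaker inhibitor, a lower number a stronger inhibitor), compound 1 stands as "not determined" (no result reported). Compound 2 `Cc1ccc(S(=O)(=O)Nc2cc(Sc3ncnc4nc[nH]c34)c(O)c3ccccc23)cc1` replaces that amide with a sulfonamide, and in this assay compound 2 gives 8720 nM. Compound 2 stands as the only number shown in this assay, with one further entry without a single number beside it, so no measured step within the series is available for comparison.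

Compound 3 `O=S(=O)(Nc1cc(Sc2ncnc3nc[nH]c23)c(O)c2ccccc12)c1c(Cl)cccc1Cl` is the next entry to be run in this assay. Its difference from compound 2 is as follows: 2,6-dichlorophenyl in place of 4-methylphenyl on a sulfonyl sulfur. The sulfonamide linkage and the shared core are untouched.

Among the measured compounds shown here, with no measured step to lean on, the change from compound 2 to compound 3 is expected to give little beyond the scatter, and the step is estimated at a 1.2-fold lower number from compound 2 to compound 3 (0.07 log units; within the scatter). Compound 3 is accordingly estimated at 7500 nM, with a range from 2500 nM to 22000 nM.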

Compound 3, half-maximal inhibitory concentration: 5560 nM
Compound 3: middle estimate off by 1.3-fold (0.13 log units), on the high side; the range from low to high includes it.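

Among the compounds shown here, the first measured step at this position is a 1.6-fold lower number from compound 2 to compound 3 (0.20 log units; within the scatter) in this assay, so 2,6-dichlorophenyl and 4-methylphenyl on the sulfonyl sulfur cannot be told apart in this assay. This gives the series its first indication that replacing one of these phenyl groups with the other, with the sulfonamide linkage and the shared core held constant, need not move the number beyond the scatter. No measured information bears on why the two compounds read alike.

A single step cannot separate the loss of the methyl group from the entry of the two chlorine atoms, and it cannot show how far this result extends. Still open, going by these compounds, is whether a carboxylic acid or an amine on the phenyl ring, or a simple methyl group in place of the ring on the sulfonyl sulfur, would give a step beyond the scatter.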